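The source may report more compounds than this note shows. Statements on the series, on what has been measured and on what is new or still open speak of the compounds shown alone.

The series rests on a shared core carrying a dichlorophenyl group and a saturated ring, and two compounds of it have been measured in a functional assay on LNCaP cells (Homo sapiens) for antiproliferative activity; a lower number here means a stronger inhibitor, a higher number a weaker inhibitor. Compound 1 `Cn1ncc(Cl)c1-c1cc(C(=O)N[C@@H]2CN[C@H](CC(=O)NC3CC3)C[C@H]2c2ccc(Cl)c(Cl)c2)oc1Cl` gives 190 nM there. Compound 2 `Cn1ncc(Cl)c1-c1cc(C(=O)N[C@@H]2CN[C@H](CCO)C[C@H]2c2ccc(Cl)c(Cl)c2)oc1Cl`, in which the chain carbon bears a hydroxymethyl in place of cyclopropylcarbamoyl, gives 160 nM in this assay. The step of a 1.2-fold lower number from compound 1 to compound 2 (0.07 log units; within the scatter) shows that the two are indistinguishable. Compound 2 thus stands at the lower of the two numbers seen so far, with compound 1 within the scatter of it.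

Compound 3 `Cn1ncc(Cl)c1-c1cc(C(=O)N[C@@H]2CN[C@H](CCCO)C[C@H]2c2ccc(Cl)c(Cl)c2)oc1Cl` is the next member: the change from compound 2 is hydroxymethyl in place of hydroxy on a saturated chain carbon, two bonds along the chain from a saturated ring carbon, so that the same difference, read one bond further out, is 2-hydroxyethyl to 3-hydroxypropyl. Going by the values given here, the only measured step, from compound 1 to compound 2, touched this chain and was within the scatter, which hints that this part of the molecule tolerates alteration, but nothing measured covers lengthening the chain itself. The expectation for compound 3 in this assay is therefore a step of a 1.1-fold higher number from compound 2 to compound 3 (0.03 log units; within the scatter), that is, no movement beyond the scatter. Compound 3 is estimated at 170 nM, with a range from 80 nM to 360 nM.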

Compound 3, half-maximal inhibitory concentration: 210 nM
The estimate for compound 3 lay 1.2-fold (0.09 log units) below the measured number; the measured number falls inside the stated range.
By their numbers in this assay, from the lowest: compounds 2, 1 and 3 (each within the scatter of the next).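

Setting hydroxymethyl in place of hydroxy on a saturated chain carbon, two bonds along the chain from a saturated ring carbon, gives a 1.3-fold higher number from compound 2 to compound 3 (0.12 log units; within the scatter) in this assay, the first measured sign that the length of this hydroxy-bearing chain can differ without the number leaving the scatter. The other new step, a 1.1-fold higher number from compound 1 to compound 3 (0.04 log units; within the scatter), replaces cyclopropylcarbamoyl with 2-hydroxyethyl and is also within the scatter, so compound 1 and compound 3 cannot be told apart in this assay, just as the steps printed for compound 2 cannot separate it from either of them. Nothing available bears on what lies behind this result.

The compounds shown leave open whether an amine or a carboxylic acid in place of the hydroxy, or a longer chain such as 4-hydroxybutyl, would move the number beyond the scatter. They also leave open whether a methyl ether of the hydroxy, or a chain with no oxygen at all, would stay within it.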